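Notes on an untested change at the saturated ring carbon

The compounds below may be only part of what the source reports. "The series", "measured", "known", "first", "only" and "open" are said of these compounds alone.

compound 1 `CC1=C(C(=O)Nc2ccc([N+](=O)[O-])cc2)C(c2ccc(Br)cc2)N=C(SCc2ccccc2Cl)N1`: 6.7%
compound 2 `CC1=C(C(=O)Nc2ccc([N+](=O)[O-])cc2)C(c2ccc(Br)cc2)N=C(SCc2cccc(Cl)c2)N1`: 4.1%
compound 3 `CC1=C(C(=O)Nc2ccc([N+](=O)[O-])cc2)C(c2ccc(Br)cc2)N=C(SCc2ccc(F)cc2)N1`: 9.7%

The three measured compounds share one core and differ only in the aryl group on a saturated chain carbon bound to a sulfur. In a functional assay on the whole organism (artery, strain albino) with Rattus norvegicus as the target, with a stated time of 60 min, at a dose of 10 mg/kg by the oral route (on this read-out lower numbers stand for less inhibition and higher numbers for more inhibition at the one dose given (going by the name of the read-out)), compound 1 gives 6.7%, the second highest of the three numbers; compound 2 lies nearest, a number 2.6 percentage points lower from compound 1 to compound 2 (within the scatter), and compound 3 furthest, a number 3 percentage points higher from compound 1 to compound 3 (within the scatter). Between the other two the difference is a number 5.6 percentage points higher from compound 2 to compound 3 (within the scatter). All three steps stay within the scatter, so no order among the three compounds can be read from them.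

Compound 4 `CC1=C(C(=O)Nc2ccc([N+](=O)[O-])cc2)C(c2cccc([N+](=O)[O-])c2)N=C(SCc2ccccc2Cl)N1` is not yet measured. It departs from compound 1 at a different place: 3-nitrophenyl in place of 4-bromophenyl on a saturated ring carbon. For the measured compounds named here, none of the measured steps touches the saturated ring carbon; each exchanges the aryl group on the saturated chain carbon bound to a sulfur, and each stayed within the scatter. Going by the values given here, no measured step therefore bears on the change to compound 4, and a change at the saturated ring carbon is untested. With the three measured values all low and close together, the default expectation is no step beyond the scatter in either direction. Compound 4 is expected to show a number 0.3 percentage points higher from compound 1 to compound 4 (within the scatter). Among the compounds with values here, the estimate for compound 4 is 7%, with a range from 0% to 20%; the range is kept wide, as no measured step addresses this position.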

Compound 4, a percentage reported as inhibition, in the whole organism at one dose (the size of the read-out at that dose, not a potency): 6.7%
Estimate against measurement, compound 4: 0.3 percentage points above, within the range that was stated.
By their numbers in this assay, from the lowest: compounds 2, 1, 4 and 3 (each within the scatter of the next).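

In this assay, for the compounds shown here, 3-nitrophenyl in place of 4-bromophenyl on the saturated ring carbon gives no change at the digits printed from compound 1 to compound 4 (within the scatter), the first reading at this position. The two groups differ in heavy-atom count, and the entering group carries hydrogen-bond acceptors where the leaving group has none, yet this difference does not separate compound 1 and compound 4 on this read-out at the one dose given. No supporting data bear on why the exchange leaves the read-out within the scatter.

The compounds shown leave open whether a saturated ring carbon bearing something other than a substituted phenyl, such as an amine, a carboxylic acid or a longer alkyl chain, would give a step beyond the scatter. Going by these compounds alone, also open is whether the exchange to 3-nitrophenyl would read the same with the 3-chlorobenzyl or 4-fluorobenzyl group on the sulfur, since the only step at this position carries the 2-chlorobenzyl group.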